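Regiochemistry of the dimethylphenyl and half-life on rat microsomes

This account rests on a few compounds, and the source may have more. Where it says the series, first, only, none or still open, it means among the compounds named here.

Going by the values given here, compound 1 `Cc1ccc(C)c(-c2nc(CN3CCC(C(=O)NCCCN4C[C@H](C)C[C@H](C)C4)CC3)c(C)o2)c1` is the only member of this series with a number in an ADME assay on microsomes from liver (Rattus norvegicus) for metabolic stability, read by LC-MS, using NADPH, at 37 degrees C; a lower number here means that the compound disappears faster, a higher number that the compound lasts longer: compound 1 gives 0.5 h. Compound 2 `Cc1ccccc1-c1nc(CN2CCC(C(=O)NCCN3C[C@H](C)C[C@H](C)C3)CC2)c(C)o1` returns only a limit of this assay, > 0.5 h, so compound 1 stands alone on the single number shown. The limit is stated at the limit of > 0.5 h in this assay, at which 1 of the 2 values shown sits. Compound 3 `Cc1ccc(-c2nc(CN3CCC(C(=O)NCCCN4C[C@H](C)C[C@H](C)C4)CC3)c(C)o2)cc1C` is not yet measured; it differs from compound 1 by 3,4-dimethylphenyl in place of 2,5-dimethylphenyl on an aromatic carbon. Among the compounds with values here, no measured step of this kind exists, so no direction is expected beyond the scatter, and the step of no change at the digits printed from compound 1 to compound 3 (within the scatter) is estimated as flat. Compound 3 is expected to give 0.5 h, within 0.25 h to 1 h.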

Compound 3, half-life: > 0.5 h
Compound 3 was reported as a limit; the forecaster's own chance of this, stated with the estimate: 50%; the middle value lies on the limit itself.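

In this assay, 3,4-dimethylphenyl in place of 2,5-dimethylphenyl gives the first step readable at this position: a number no lower from compound 1 to compound 3 (the limit leaves the size open). The value of compound 3 is a limit, so this step has a direction but no readable size, and moving the two methyl groups shows no shorter half-life. Most of the values shown now sit on this limit: the limit of > 0.5 h in this assay, at which 2 of the 3 values shown sit.

From the compounds shown here alone, how far the half-life of compound 3 lies from that of compound 1 remains open. So does the outcome with an unsubstituted phenyl, a methoxyphenyl or a chlorophenyl in place of the dimethylphenyl.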